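This account rests on a few compounds, and the source may have more. Where it says the series, first, only, none or still open, it means among the compounds named here.

Compound 1, `COC(=O)c1ccc(NCc2cncn2Cc2ccc(-c3ccccc3)cc2)cc1-c1ccccc1`, was examined in a toxicity assay on NIH3T3 cells (Mus musculus) for cytotoxicity, read by resazurin assay; on this read-out higher numbers stand for an effect only at larger amounts of compound and lower numbers for an effect already at smaller amounts. In this assay compound 1 gives > 1000 nM, which is a limit of the assay rather than a measured number. Going by the values given here, compound 2, `c1ccc(-c2ccc(Cn3cncc3CNc3ccc(-c4cncs4)c(-c4ccccc4)c3)cc2)cc1`, is the only other compound with a reading here. In this assay compound 2 gives > 1000 nM, again a limit and not a number. Among the compounds with values here, the one measured step, a step that the two limits leave unreadable from compound 1 to compound 2, cannot be sized because both readings sit at the limit of > 1000 nM in this assay, at which 2 of the 2 values shown sit. Compound 3, `COC(=O)c1ccc(NCc2cncn2Cc2cccc(C(C)(C)C)c2)cc1-c1ccccc1`, has not yet been measured. Its difference from compound 1 is 3-(tert-butyl)phenyl in place of 4-phenylphenyl on a saturated chain carbon bound to an aromatic nitrogen. Within the data shown here, no measured step touches this part of the molecule, and the single step that exists cannot be read for size, so the data give no direction for this change. Compound 3 is therefore expected to give a value around 3000 nM, with a range from 800 nM to 20000 nM, and most probably it will again be reported only as a limit. The expected step, a step that the limit leaves unreadable from compound 1 to compound 3, means that no change beyond the scatter is anticipated.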

Compound 3, half-maximal effective concentration: > 1000 nM
Compound 3: a limit, no number; the forecaster's own chance of this, stated with the estimate: 85%; the middle value does not contradict the limit.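

The step from compound 1 to compound 3 cannot be read, since both readings are limits of the assay and not numbers: the limit of > 1000 nM in this assay, at which 3 of the 3 values shown sit. The compounds shown leave open at what amount any of them would affect the cells in this assay, and whether 3-(tert-butyl)phenyl in place of 4-phenylphenyl changes that amount at all.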